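Replacing phenyl in compound 2: notes toward compound 3

A few compounds are considered here, and "the series" means these few. Any claim that something is new, unique, unknown or untested is made for them only; others in the source may bear on it.

- Compound 1 `COc1ccc(-c2cc(-c3cc(OC)c(OC)c(OC)c3)nc(-c3ccccc3)n2)c(OC)c1`: 1440 nM
- Compound 2 `COc1cc(-c2cc(-c3ccccc3)nc(-c3ccccc3)n2)cc(OC)c1OC`: 5870 nM

In a functional assay on MDA-MB-231 cells (Homo sapiens) for inhibition, read by MTT assay, with a stated time of 48 h (a higher number here means a weaker inhibitor, a lower number a stronger inhibitor), compound 2 holds the higher of the two numbers, 5870 nM, which makes it the weaker inhibitor of the pair. Compound 3 `COc1cc(-c2cc(-c3ccc(O)cc3O)nc(-c3ccccc3)n2)cc(OC)c1OC` carries 2,4-dihydroxyphenyl in place of phenyl on an aromatic carbon next to the ring nitrogen (2,4-dihydroxyphenyl in place of phenyl on an aromatic carbon). Within the data shown here, one measured step bears on this change: a 4.1-fold higher number from compound 1 to compound 2 (0.61 log units; beyond the scatter), where phenyl takes the place of 2,4-dimethoxyphenyl. That is a single modest step, and it involves methoxy groups, not hydroxy groups, so the read-across is loose. A fall of similar size in this assay is still expected on going to the substituted ring. The expected step is a 3.5-fold lower number from compound 2 to compound 3 (0.54 log units; beyond the scatter). Compound 3 is estimated at 1700 nM, with an expected range of 450 nM to 6000 nM.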

Compound 3, half-maximal inhibitory concentration: 810 nM
Estimate against measurement, compound 3: 2.1-fold (0.32 log units) above; the range from low to high includes it.
By their numbers in this assay, from the lowest: compounds 3 and 1 (each within the scatter of the next); then compound 2.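

In this assay, putting 2,4-dihydroxyphenyl on this aromatic carbon next to the ring nitrogen gives a 7.2-fold lower number from compound 2 to compound 3 (0.86 log units; beyond the scatter) and shows that the advantage of a substituted ring over phenyl at this position is not confined to the methoxy-bearing ring of compound 1. Against 2,4-dimethoxyphenyl the change gives a 1.8-fold lower number from compound 1 to compound 3 (0.25 log units; within the scatter) and leaves the two substituted rings unseparated, so exchanging the methoxy groups for hydroxy groups has no readable effect on the number here. No measurement is available that could explain either step.

The compounds shown leave open whether both hydroxy groups are needed or a single one would serve on this ring. On these data alone, it also remains open how an amine or a carboxylic acid on this ring would compare with the hydroxy and methoxy groups.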